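Adenosine analogues with varied benzylamine groups against G-361 cells

This account rests on a few compounds, and the source may have more. Where it says the series, first, only, none or still open, it means among the compounds named here.

Measured compounds:
compound 1, `COc1ccc(CNc2ncnc3c2ncn3[C@@H]2O[C@H](CO)[C@@H](O)[C@H]2O)c(OC)c1`, "not determined" (no result reported)
compound 2, `OC[C@H]1O[C@@H](n2cnc3c(NCc4ccc(F)cc4Cl)ncnc32)[C@H](O)[C@@H]1O`, > 166000 nM

In a functional assay on G-361 cells (Homo sapiens) for antiproliferative activity, with a stated time of 72 h (on this read-out lower numbers stand for stronger inhibition and higher numbers for weaker inhibition), compound 1 gives "not determined" (no result reported), so no number is available for it. Compound 2 gives > 166000 nM, and this is a limit of this assay, not a number. Within the data shown here, compound 2 therefore stands at the limit of > 166000 nM in this assay, at which 1 of the 2 values shown sits, and no step between two measured compounds can be read from these two entries.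

Compound 3, `COc1cccc(CNc2ncnc3c2ncn3[C@@H]2O[C@H](CO)[C@@H](O)[C@H]2O)c1O`, is not yet measured. It differs from compound 2 in one place: 2-hydroxy-3-methoxyphenyl in place of 2-chloro-4-fluorophenyl on a saturated chain carbon bound to a nitrogen on an aromatic ring. Among the measured compounds shown here, with no measured step to lean on, the expectation for this change is a small move, within the usual scatter, in the direction of weaker or unchanged inhibition. Compound 3 is estimated at 120000 nM, with a range from 25000 nM to 250000 nM, which means an expected step of an at least 1.3-fold lower number from compound 2 to compound 3 (0.14 log units; that floor lies within the scatter).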

Compound 3, half-maximal inhibitory concentration: 148000 nM
Compound 3: middle estimate off by 1.2-fold (0.09 log units), on the low side, and the stated range covers the measured number.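

Compound 2 stands at > 166000 nM in this assay, which is a limit of the assay and not a number. Among these compounds, compound 3 brings the first actual number, 148000 nM. With 2-hydroxy-3-methoxyphenyl in place of 2-chloro-4-fluorophenyl on a saturated chain carbon bound to a nitrogen on an aromatic ring, the change can now be read as an at least 1.1-fold lower number from compound 2 to compound 3 (0.04 log units; that floor lies within the scatter), but only as a floor, since its starting point is a limit: the limit of > 166000 nM in this assay, at which 1 of the 3 values shown sits.

The compounds shown leave open how far the true value of compound 2 lies from its limit, and whether the hydroxy or the methoxy group of compound 3 matters on its own. They also do not tell what an amine or a carboxylic acid on the phenyl ring, or a longer chain to that ring, would do in this assay.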